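The compounds below may be only part of what the source reports. "The series", "measured", "known", "first", "only" and "open" are said of these compounds alone.

Compound 1 `COc1ccc(-c2cc3ccccc3nc2C=O)cc1`: > 10000 nM
Compound 2 `COc1ccc(-c2cc3ccccc3nc2/C=C/C(=O)c2ccc(F)cc2)cc1`: 810 nM

In a functional assay on SK-BR-3 cells (Homo sapiens) for antiproliferative activity, read by XTT assay, with a stated time of 72 h (on this read-out lower numbers stand for stronger inhibition and higher numbers for weaker inhibition), compound 1 reads > 10000 nM, which is a limit of the assay and not a number. Going by the values given here, compound 2 gives 810 nM, the only actual number so far. Compound 3 `COc1ccc(C(=O)/C=C/c2nc3ccccc3cc2-c2ccc(OC)cc2)cc1` carries methoxy in place of fluoro on an aromatic carbon, para to a large group (methoxy in place of fluoro on an aromatic carbon). Among the compounds with values here, no measured step shows what this change does in this assay. The estimated change a 1.1-fold lower number from compound 2 to compound 3 (0.03 log units; within the scatter) is expected to stay within the usual scatter, with neither direction favoured. The expected value for compound 3 is 750 nM, in a range of 220 nM to 2800 nM.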

Compound 3, half-maximal inhibitory concentration: 9280 nM
Compound 3: the middle estimate sits 12-fold (1.09 log units) below what was measured, and the stated range ends below it.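

The 4-fluorophenyl on the carbonyl cannot be exchanged for 4-methoxyphenyl without cost: in this assay, the change gives an 11-fold higher number from compound 2 to compound 3 (1.06 log units; beyond the scatter). Going by these compounds alone, this is the first step to show that this position, para to a large group, responds strongly to what it carries. Compound 3 now reads close to where the read-out stops giving numbers: the limit of > 10000 nM in this assay, at which 1 of the 3 values shown sits.

As far as these compounds go, whether the loss belongs to methoxy alone stays open. This single step cannot say how chloro, hydroxyl or an amine on the same aromatic carbon would read.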